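The source may hold more compounds than are shown below. What is called first, only, known or untested is meant among the compounds shown, and "the series" means these compounds.

Working notes on the series in a functional assay on HCT-116 cells (Homo sapiens) for cytotoxicity, read by MTT assay, with a stated time of 48 h; on this read-out lower numbers stand for stronger inhibition and higher numbers for weaker inhibition.

Compound 2 `O=C(CC1c2ccccc2N=C(SCCCCCN2CCCC2)N1c1ccc(-c2ccc(F)cc2)cc1)NCc1ccc(F)cc1` gives 7700 nM in this assay, the second highest of the three numbers recorded. Compound 1 `O=C(CC1c2ccccc2N=C(SCCCCCN2CCCC2)N1c1ccc(-c2ccccc2)cc1)NCc1ccc(F)cc1` gives 6200 nM in this assay, and compound 3 `O=C(CC1c2ccccc2N=C(SCCCCCN2CCCC2)N1c1ccc(-c2ccc(F)cc2)cc1)NCc1ccccc1` gives 12500 nM in this assay; both sit within the scatter of compound 2, so no order among the three can be read.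

Compound 4 `O=C(CC1c2ccccc2N=C(SCCCCCN2CCCC2)N1c1ccccc1)NCc1ccc(F)cc1` differs from compound 2 by hydrogen in place of 4-fluorophenyl on an aromatic carbon, on an aromatic carbon of a six-membered aromatic ring of carbon only, para to a large group. For the measured compounds named here, no measured step removes this whole aryl group; the two measured steps, a 1.2-fold higher number from compound 1 to compound 2 (0.09 log units; within the scatter) and a 1.6-fold higher number from compound 2 to compound 3 (0.21 log units; within the scatter), concern only a fluorine swap and both stay within the scatter. They show the fluorine on the outer ring hardly matters, but say nothing about losing the ring itself. The expected step of a 1.3-fold higher number from compound 2 to compound 4 (0.11 log units; within the scatter) is therefore uncertain, with no direction beyond the scatter firmly expected. Compound 4 is estimated at 10000 nM in this assay, within 3000 nM to 40000 nM.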

Compound 4, half-maximal inhibitory concentration: 27100 nM
The estimate for compound 4 lay 2.7-fold (0.43 log units) below the measured number; the measured number falls inside the stated range.
By their numbers in this assay, from the lowest: compounds 1, 2 and 3 (each within the scatter of the next); then compound 4.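

In this assay, the outer ring at this position counts for more than the fluorine it carries: the change to hydrogen gives a 3.5-fold higher number from compound 2 to compound 4 (0.55 log units; beyond the scatter) and a 4.4-fold higher number from compound 1 to compound 4 (0.64 log units; beyond the scatter), both modest but beyond the scatter, whereas the fluorine swaps stayed within it. For the compounds shown here, this is the first single change to go beyond the scatter, and it runs the same way whether 4-fluorophenyl or phenyl leaves the aromatic carbon para to a large group. No measurement at hand bears on why removing the outer ring has this effect.

As far as these compounds go, whether a small group such as methoxy or chloro in this place keeps the number close to that of compound 2 remains open. Also open, from the compounds shown here alone, is how an amine or a carboxylic acid would behave on the same carbon.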